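Replacing a Pyridinylsulfanyl Group with a Methylimidazolyl Group

The source may hold more compounds than are shown below. What is called first, only, known or untested is meant among the compounds shown, and "the series" means these compounds.

Measured compounds:
compound 1 `Cc1cc(F)c(S(C)(=O)=O)cc1C(=O)N=C(N)N` gives 44 nM
compound 2 `Cc1cc(SC(C)C)c(S(C)(=O)=O)cc1C(=O)N=C(N)N` gives 12 nM
compound 3 `Cc1cc(Sc2ccncc2)c(S(C)(=O)=O)cc1C(=O)N=C(N)N` gives 13 nM

The three measured compounds share one core and differ only at the aromatic carbon ortho to the methylsulfonyl group. In a functional assay for inhibition of sodium/hydrogen exchanger (Oryctolagus cuniculus) (a higher number here means a weaker inhibitor, a lower number a stronger inhibitor), compound 1 carries fluoro at that carbon and gives 44 nM. Putting a thioether there helps in both measured cases: a 3.7-fold lower number from compound 1 to compound 2 (0.56 log units; beyond the scatter) and a 3.4-fold lower number from compound 1 to compound 3 (0.53 log units; beyond the scatter). The two thioethers are not separable, since a 1.1-fold higher number from compound 2 to compound 3 (0.03 log units; within the scatter). Compound 3 therefore stands with compound 2 at the lower end of the numbers seen so far, clearly apart from compound 1.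

Compound 4 `Cc1cn(-c2cc(C)c(C(=O)N=C(N)N)cc2S(C)(=O)=O)cn1` takes the next step: 4-methyl-1H-imidazol-1-yl in place of (pyridin-4-yl)sulfanyl on an aromatic carbon. Within the data shown here, no measured step covers a ring bound directly to this carbon through nitrogen rather than through sulfur. What the measured steps do show is that a group larger than fluoro at this carbon has so far given a lower number in this assay than compound 1, and that the nature of that group mattered little when compound 2 and compound 3 are compared. On that basis compound 4 is expected to stay close to compound 3, with a step of a 1.2-fold higher number from compound 3 to compound 4 (0.09 log units; within the scatter), within the scatter. The estimate for compound 4 in this assay is 16 nM, with a range from 5 nM to 50 nM.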

Compound 4, half-maximal inhibitory concentration: 28 nM
Estimate against measurement, compound 4: 1.8-fold (0.24 log units) below, within the range that was stated.
By their numbers in this assay, from the lowest: compounds 2 and 3 (each within the scatter of the next); then compounds 4 and 1 (each within the scatter of the next).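

The position proves less forgiving than the two thioethers suggested: in this assay, the 4-methyl-1H-imidazol-1-yl group separates from both sulfur-linked groups, with modest steps in the weaker direction (a 2.2-fold higher number from compound 3 to compound 4 (0.33 log units; beyond the scatter)) and (a 2.3-fold higher number from compound 2 to compound 4 (0.37 log units; beyond the scatter)). The gain that both thioethers showed over fluoro does not extend to every larger group at this carbon, since compound 4 cannot be told apart from compound 1 (a 1.6-fold lower number from compound 1 to compound 4 (0.20 log units; within the scatter)). Nothing among the data accounts for this loss, so the shift remains an observation without an explanation.

Because the change from compound 3 to compound 4 alters the link to the shared core and the ring together, the compounds shown cannot assign the shift to the loss of sulfur, to the ring size or to the added methyl group. On these data alone, how a pyridin-4-yl ring bound directly to this carbon, an imidazol-1-yl ring without its methyl group, an amine or a longer chain would read at this carbon remains open.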